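Pyrrolidinyl in place of methylpiperazinyl: expected solubility

This account rests on a few compounds, and the source may have more. Where it says the series, first, only, none or still open, it means among the compounds named here.

Three measured compounds share one core. Compound 1 `CC(=O)N1CCC(c2nc(NCc3ccccn3)ncc2-c2cc(C)no2)CC1` gives 221000 nM in a physicochemical assay for solubility, with a stated time of 24 h, at pH 3; on this read-out lower numbers stand for lower solubility and higher numbers for higher solubility; compound 2 `CC(=O)N1CCC(c2nc(N3CCN(C)CC3)ncc2-c2cc(C)no2)CC1` gives 225000 nM; compound 3 `CC(=O)N1CCC(c2nc(NCc3cccnc3)ncc2-c2cc(C)no2)CC1` gives 238000 nM. Compound 2 stands second highest of the three numbers, and the steps of a 1.0-fold higher number from compound 1 to compound 2 (0.01 log units; within the scatter), a 1.1-fold higher number from compound 2 to compound 3 (0.02 log units; within the scatter) and a 1.1-fold higher number from compound 1 to compound 3 (0.03 log units; within the scatter) all lie within the scatter. Compound 4 `CC(=O)N1CCC(c2nc(N3CCCC3)ncc2-c2cc(C)no2)CC1` differs from compound 2 in one place: pyrrolidin-1-yl in place of 4-methylpiperazin-1-yl on an aromatic carbon. The steps of a 1.0-fold higher number from compound 1 to compound 2 (0.01 log units; within the scatter) and a 1.1-fold higher number from compound 2 to compound 3 (0.02 log units; within the scatter) exchanged the group at this same position without a step beyond the scatter, though none of them brought in a pyrrolidin-1-yl group. The step of a 1.7-fold lower number from compound 2 to compound 4 (0.24 log units; within the scatter) is therefore expected to stay small. Compound 4 is estimated at 130000 nM, within 30000 nM to 280000 nM.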

Compound 4, solubility: 207000 nM
Estimate against measurement, compound 4: 1.6-fold (0.20 log units) below, and the stated range covers the measured number.
By their numbers in this assay, from the lowest: compounds 4, 1, 2 and 3 (each within the scatter of the next).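

In this assay, pyrrolidin-1-yl, which has one hetero atom in its ring against two in 4-methylpiperazin-1-yl, gives a 1.1-fold lower number from compound 2 to compound 4 (0.04 log units; within the scatter). Against the two pyridinylmethylamino groups, the same group gives a 1.1-fold lower number from compound 3 to compound 4 (0.06 log units; within the scatter) and a 1.1-fold lower number from compound 1 to compound 4 (0.03 log units; within the scatter), so all four groups at this position now lie within the scatter of one another. Nothing shown gives a cause for this.

Going by these compounds, it stays open whether a carboxylic acid or a primary amine at this position would give a step beyond the scatter. The same question stands for a longer alkyl chain.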